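The source may report more compounds than this note shows. Statements on the series, on what has been measured and on what is new or still open speak of the compounds shown alone.

In a functional assay on SK-BR-3 cells (Homo sapiens) for antiproliferative activity, read by MTT assay, with a stated time of 72 h (a lower number here means a stronger inhibitor, a higher number a weaker inhibitor), compound 1 `CCN1CCN(c2cc(C)c3cc(NC(=O)c4ccc[nH]4)ccc3n2)CC1` gives 13200 nM and compound 2 `CCN1CCN(c2cc(C)c3cc(NC(=O)c4ccc(C)cc4)ccc3n2)CC1` gives 11400 nM while compound 3 `CCN1CCN(c2cc(C)c3cc(NC(=O)c4cc5ccccc5[nH]4)ccc3n2)CC1` stands lowest of the three at 2550 nM with both steps to it beyond the scatter. Compound 4 `CCN1CCN(c2cc(C)c3cc(NC(=O)c4ccco4)ccc3n2)CC1` carries furan-2-yl in place of 1H-indol-2-yl on a carbonyl carbon. No furan-2-yl amide has been measured, so the guides are the modest steps that reach 1H-indol-2-yl (a 5.2-fold lower number from compound 1 to compound 3 (0.71 log units; beyond the scatter) and a 4.5-fold lower number from compound 2 to compound 3 (0.65 log units; beyond the scatter)) while the step between the other two amides (a 1.2-fold lower number from compound 1 to compound 2 (0.06 log units; within the scatter)) stays within the scatter. Leaving 1H-indol-2-yl should therefore undo a step of that modest size in this assay toward a higher number. The expected move is a 4.3-fold higher number from compound 3 to compound 4 (0.63 log units; beyond the scatter) in the estimate made here. Compound 4 is expected at 11000 nM (estimated range 5500 nM to 22000 nM).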

Compound 4, half-maximal inhibitory concentration: 37500 nM
The estimate for compound 4 lay 3.4-fold (0.53 log units) below the measured number; the whole stated range lies below it.
By their numbers in this assay, from the lowest: compound 3; then compounds 2 and 1 (each within the scatter of the next); then compound 4.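

In this assay the furan-2-yl amide stands apart from all three earlier amides: a 15-fold higher number from compound 3 to compound 4 (1.17 log units; beyond the scatter) and a 3.3-fold higher number from compound 2 to compound 4 (0.52 log units; beyond the scatter) and a 2.8-fold higher number from compound 1 to compound 4 (0.45 log units; beyond the scatter). The 1H-pyrrol-2-yl and 4-methylphenyl amides therefore did not mark the high end at this position, and compound 1 and compound 4 show that one five-membered aromatic ring with 1 hetero atom does not settle the number. No available measurement bears on the reason for these gaps. Open, from the compounds shown here alone, is where a benzofuran-2-yl or thiophene-2-yl amide on the same carbonyl carbon would fall relative to compound 3 and compound 4.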